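The source may report more compounds than this note shows. Statements on the series, on what has been measured and on what is new or still open speak of the compounds shown alone.

Compound 1 `COc1cc(/C=C/C(=O)C2=C(/C=C/c3ccc(O)c(OC)c3)NC(=O)NC2c2ccccc2O)ccc1O` and compound 2 `COc1cc(/C=C/C(=O)C2=C(/C=C/c3ccc(O)c(OC)c3)NC(=O)NC2c2ccc(N(C)C)cc2)ccc1O` share one core and differ only at a saturated ring carbon. In a functional assay, with a stated time of 20 min, tested at 50 uM (on this read-out higher numbers stand for a stronger effect at the one concentration tested and lower numbers for a weaker effect), compound 1 gives 88.9%, while compound 2 gives 56%; compound 2 thus stands lowest of the two numbers, and the step of a number 32.9 percentage points lower from compound 1 to compound 2 (beyond the scatter) lies beyond the scatter. Compound 3 `COc1cc(/C=C/C(=O)C2=C(/C=C/c3ccc(O)c(OC)c3)NC(=O)NC2c2c(Cl)cccc2Cl)ccc1O` changes the same position again: 2,6-dichlorophenyl in place of 4-(dimethylamino)phenyl on a saturated ring carbon. Among the measured compounds shown here, no measured step involves 2,6-dichlorophenyl, so only the single large step at this position shows that the aryl group matters here. Compound 3 is therefore expected to give 65% in this assay, between 40% and 90%, a step of a number 9 percentage points higher from compound 2 to compound 3 (within the scatter) that is estimated with little confidence.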

Compound 3, a percentage reported as activity, at one concentration (the size of the read-out at that concentration, not a potency): 43.2%
Compound 3: the middle estimate sits 21.8 percentage points above what was measured, and the stated range covers the measured number.
By their numbers in this assay, from the lowest: compound 3; then compound 2; then compound 1.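

Among the compounds shown here, at this saturated ring carbon, 2,6-dichlorophenyl in place of 4-(dimethylamino)phenyl gives a number 12.8 percentage points lower from compound 2 to compound 3 (beyond the scatter) in this assay, so the three aryl groups now separate into a full order, each step beyond the scatter. 2,6-dichlorophenyl in place of 2-hydroxyphenyl gives a number 45.7 percentage points lower from compound 1 to compound 3 (beyond the scatter), the widest step at this position so far. Nothing available explains why these aryl groups differ. The compounds shown leave open whether the hydroxyl group of compound 1 is what matters, since neither an unsubstituted phenyl nor a 2-methoxyphenyl stands among them. They also leave open whether a single chlorine would behave like the pair.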